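The compounds below may be only part of what the source reports. "The series", "measured", "known", "first", "only" and "open" are said of these compounds alone.

Among the measured compounds shown here, measured in a functional assay on MCF7 cells (Homo sapiens) for cytotoxicity, read by MTT assay (a higher number here means a weaker inhibitor, a lower number a stronger inhibitor), compound 1 `COc1ccc(/C=C/C(=O)c2ccc(OCC3CO3)cc2)cc1` gives 11600 nM and holds the higher of the two numbers known so far. In this assay compound 2 `O=C(/C=C/c1ccc(OCC2CO2)cc1)c1ccc(OCC2CO2)cc1` gives 3870 nM and carries a second oxiran-2-yl group. Compound 3 `COc1ccc(/C=C/C(=O)c2ccc(OCC(O)CCl)cc2)cc1` has not been measured yet. It differs from compound 1 in one place: 2-chloro-1-hydroxyethyl in place of oxiran-2-yl on a saturated chain carbon bound to an oxygen on an aromatic ring. In words, 2-chloro-1-hydroxyethyl replaces oxiran-2-yl on a saturated chain carbon bound to an oxygen on an aromatic ring. For the measured compounds named here, no measured pair shows this exact swap. Going by the values given here, the only guide is the modest step of a 3.0-fold lower number from compound 1 to compound 2 (0.48 log units; beyond the scatter) and that step adds an oxiran-2-yl group in place of a hydrogen rather than replacing one. It hints that this group can matter in this assay but says little about the size or direction of the new change. The expected step is therefore small, with a 1.1-fold higher number from compound 1 to compound 3 (0.05 log units; within the scatter) as an estimate that stays within the scatter. For compound 3 the estimated value is 13000 nM with an expected range from 5000 nM to 32000 nM in this estimate.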

Compound 3, half-maximal inhibitory concentration: 18500 nM
Estimate against measurement, compound 3: 1.4-fold (0.15 log units) below; measured number inside the range.
By their numbers in this assay, from the lowest: compound 2; then compounds 1 and 3 (each within the scatter of the next).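

Among the compounds shown here, replacing oxiran-2-yl with 2-chloro-1-hydroxyethyl on a saturated chain carbon bound to an oxygen on an aromatic ring gives a 1.6-fold higher number from compound 1 to compound 3 (0.20 log units; within the scatter) in this assay, and this is the first direct view of a change to the group itself, since the earlier step only added a second oxiran-2-yl group. The entering group has no ring and brings a chlorine and a hydrogen-bond donor, yet the two numbers stay within the usual scatter of each other, so for this pair a closed three-membered ring is not needed to keep the reading at the level of compound 1. No measurement here explains why the two groups read so alike.

Going by these compounds, what the same swap would do on compound 2, which carries a second oxiran-2-yl group, remains open. Also open, on these data alone, is how far this tolerance extends at this place, for example to an amine in place of the chlorine, or to a plain longer chain with neither chlorine nor hydroxyl.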